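Chain length of a hydroxyalkyl arm on two ring cores

A few compounds are considered here, and "the series" means these few. Any claim that something is new, unique, unknown or untested is made for them only; others in the source may bear on it.

Measured so far:
Compound 1, `OCCCN1CCC(c2nc(-c3ccc4ccccc4c3)no2)CC1`: 40400 nM
Compound 2, `OCCCCN1CCC(c2nc(-c3ccc4ccccc4c3)no2)CC1`: 1170 nM
Compound 3, `OCCCN1CCC[C@H]1c1nc(-c2ccc3ccccc3c2)no1`: 20500 nM

Of the compounds shown here, three have been tested in an assay on HepG2 cells for antagonist activity at Bile acid receptor (Homo sapiens), read by a luciferase reporter; a higher number here means a weaker inhibitor, a lower number a stronger inhibitor. Compound 1 and compound 2 share one core; compound 3 carries a different core, and the difference between the two cores is not broken down here. In this assay compound 3 gives a number close to that of compound 1, a gap within the scatter, while compound 2 sits well apart from both.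

The change from compound 1 to compound 2 is hydroxymethyl in place of hydroxy on a saturated chain carbon, three bonds along the chain from an amine nitrogen in a ring, and it made the step of a 35-fold lower number from compound 1 to compound 2 (1.54 log units; beyond the scatter).

Compound 4, `OCCCCN1CCC[C@H]1c1nc(-c2ccc3ccccc3c2)no1`, is not yet measured. It differs from compound 3 by hydroxymethyl in place of hydroxy on a saturated chain carbon, three bonds along the chain from an amine nitrogen in a ring, the same change in the same place as that from compound 1 to compound 2. Resting on the single earlier step of a 35-fold lower number from compound 1 to compound 2 (1.54 log units; beyond the scatter), the step from compound 3 to compound 4 is expected to be a 14-fold lower number from compound 3 to compound 4 (1.14 log units; beyond the scatter), taken with some caution since only one example of this change exists. Compound 4 is therefore estimated at 1500 nM, with a range from 300 nM to 7000 nM.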

Compound 4, half-maximal inhibitory concentration: 33800 nM
Compound 4: middle estimate off by 23-fold (1.35 log units), on the low side, outside the stated range (above it).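

In this assay, the change that mattered on the first core, 3-hydroxypropyl to 4-hydroxybutyl, gives a 1.6-fold higher number from compound 3 to compound 4 (0.22 log units; within the scatter) on the second core. The change therefore did not carry from one core to the other in this series, and the two cores do not respond alike: the same change on two cores in this assay, a 35-fold lower number (1.54 log units; beyond the scatter) from compound 1 to compound 2 and a 1.6-fold higher number (0.22 log units; within the scatter) from compound 3 to compound 4, 57-fold (1.76 log units) apart, beyond the scatter of two such steps. This rests on a single pair for each core, so it shows that the step cannot be assumed to transfer, but it does not show which difference between the cores is responsible or how the change would behave on any other core.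

The compounds shown leave open how a shorter or longer chain would behave on either core, and so whether the second core responds to chain length at all. On these data alone, it also remains open whether an amine or a carboxylic acid in place of the hydroxy would show the same split between the two cores.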